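The source may hold more compounds than are shown below. What is called first, only, known or untested is meant among the compounds shown, and "the series" means these compounds.

Series notes, values from a functional assay on CCRF-CEM cells (Homo sapiens) for inhibition, read by MTT assay, with a stated time of 72 h; a higher number here means a weaker inhibitor, a lower number a stronger inhibitor:
- compound 1 `COc1cc(NC(C)CCCNC(=O)Nc2cccc(F)c2)c2ncccc2c1`: 21000 nM
- compound 2 `COc1cc(NC(C)CCCNC(=O)NNC(=O)Nc2ccc(Cl)cc2)c2ncccc2c1`: 108000 nM
- compound 3 `COc1cc(NC(C)CCCNC(=O)Nc2ccc(F)cc2)c2ncccc2c1`: not yet measured

Of the two numbers, compound 2 holds the higher, at 108000 nM, and compound 1 is its nearest neighbour. The change now under consideration puts 4-fluorophenyl in place of ((4-chlorophenyl)carbamoyl)amino on an amide-type nitrogen. For the measured compounds named here, the only measured step that bears on this is a 5.1-fold higher number from compound 1 to compound 2 (0.71 log units; beyond the scatter), a modest step in which the same ((4-chlorophenyl)carbamoyl)amino group entered on that nitrogen. Its removal is therefore expected to give a step of similar size in the opposite direction in this assay, towards a lower number, though this rests on a single step. The expected move is a 4.3-fold lower number from compound 2 to compound 3 (0.64 log units; beyond the scatter). For compound 3 the estimated value is 25000 nM, with an expected range of 10000 nM to 60000 nM.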

Compound 3, half-maximal inhibitory concentration: 26000 nM
For compound 3 the middle estimate is 1.0-fold (0.02 log units) below the measured one, within the range that was stated.
By their numbers in this assay, from the lowest: compounds 1 and 3 (each within the scatter of the next); then compound 2.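

In this assay, 4-fluorophenyl in place of ((4-chlorophenyl)carbamoyl)amino on the amide-type nitrogen gives a 4.2-fold lower number from compound 2 to compound 3 (0.62 log units; beyond the scatter), so a second pair now links that larger group to the higher number. The new comparison between the two fluorophenyl groups gives a 1.2-fold higher number from compound 1 to compound 3 (0.09 log units; within the scatter), so 3-fluorophenyl and 4-fluorophenyl on this nitrogen cannot be told apart in this assay. Nothing on hand explains either step.

Compound 2 differs from compound 3 in both the chlorine and the carbamoylamino link, so the compounds shown cannot say which of these goes with its higher number; 4-chlorophenyl on the same nitrogen would separate them. Also open, from the compounds shown here alone, is whether a non-aromatic group on this nitrogen, such as cyclohexyl, or a benzyl group would move the number at all.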